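The source may report more compounds than this note shows. Statements on the series, on what has been measured and on what is new or still open speak of the compounds shown alone.

Compound 1 `N#Cc1cnc(NC(=O)N2CCN(c3ccc(Cl)c(Cl)c3)CC2)s1` gives < 1600 nM in a physicochemical assay for solubility, read by nephelometry, at pH 6.5 (on this read-out higher numbers stand for higher solubility and lower numbers for lower solubility), a limit of the assay rather than a number. Compound 2 `Cc1ccc(NC2CN(C(=O)Nc3ncc(Cl)s3)C2)cc1Cl` gives 1600 nM. Compound 3 `Cc1ccc(OCCCc2nc3cc(Cl)cnc3[nH]2)cc1Cl` gives < 1600 nM, likewise only a limit.

Compound 1 thus stands at the limit of < 1600 nM in this assay, at which 2 of the 3 values shown sit; its value and that of compound 2 give no order between them. Compound 4 `N#Cc1cnc(NC(=O)N2CCN(c3cnc(Cl)c(Cl)c3)CC2)s1` differs from compound 1 by 5,6-dichloropyridin-3-yl in place of 3,4-dichlorophenyl on an amine nitrogen in a ring. Going by the values given here, no measured step of this kind is at hand, so the expectation rests on the limit alone. The step from compound 1 to compound 4 is expected to be an at least 1.8-fold higher number from compound 1 to compound 4 (0.27 log units; that floor lies within the scatter), towards higher solubility, possibly still within the scatter. Compound 4 is estimated at 3000 nM in this assay, within 900 nM to 12000 nM, with a fair chance that only a limit is again reported.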

Compound 4, solubility: < 1600 nM
Compound 4 ended at the assay's limit (the forecaster's own chance of this, stated with the estimate: 40%); middle value at least 1.8-fold (0.27 log units) from the limit.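

Compound 1 and compound 4 both sit at a limit in this assay, so no step between them can be read: the limit of < 1600 nM in this assay, at which 3 of the 4 values shown sit.

On these data alone, whether 5,6-dichloropyridin-3-yl in place of 3,4-dichlorophenyl moves the read-out in this assay at all, and in which direction, stays open.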